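Two Analogues Measured, a Third Awaited

This account rests on a few compounds, and the source may have more. Where it says the series, first, only, none or still open, it means among the compounds named here.

Compound 1 `CCc1nn(C)c2c1C(c1cccc(Br)c1)=NCCN2`: 1.25 mg/kg
Compound 2 `Cc1cccc(C2=NCCNc3c2c(C)nn3C)c1`: 2.5 mg/kg

Of the compounds shown here, two sharing a core have been tested in a functional assay on the whole organism for positive allosteric modulation, with Rattus norvegicus as the target; a higher number here means that more compound is needed for the effect, a lower number that less compound is needed. Compound 1 gives 1.25 mg/kg in this assay, and compound 2 gives 2.5 mg/kg. Compound 2 stands at the higher of the two numbers, but its gap to compound 1 lies within the scatter, so the two cannot be ordered from these measurements alone.

Compound 3 `CCc1nn(C)c2c1C(c1cccc(C)c1)=NCCN2` has not yet been measured in this assay. It differs from compound 2 by a single change: methyl in place of hydrogen on a saturated chain carbon bound to an aromatic carbon. Among the measured compounds shown here, no measured pair shows a step of this kind, so the effect has to be judged without a precedent.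

Given this, compound 3 is expected to land close to compound 2, with the step of a 1.4-fold lower number from compound 2 to compound 3 (0.14 log units; within the scatter) expected to stay inside the usual scatter. The estimated value for compound 3 in this assay is 1.8 mg/kg, with a range from 0.6 mg/kg to 5 mg/kg.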

Compound 3, minimum effective dose: 5 mg/kg
Compound 3: the middle estimate sits 2.8-fold (0.44 log units) below what was measured; the measured number falls inside the stated range.
By their numbers in this assay, from the lowest: compounds 1, 2 and 3 (each within the scatter of the next, the first and the last beyond it).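

In this assay the change from methyl to ethyl on the saturated chain carbon bound to an aromatic carbon now has its first reading, a 2.0-fold higher number from compound 2 to compound 3 (0.30 log units; within the scatter) and so cannot be told apart from repeat measurement at this position. Among the compounds shown here, the aromatic carbon gives the clearer signal, as methyl in place of bromo there brings a 4.0-fold higher number from compound 1 to compound 3 (0.60 log units; beyond the scatter) and is the only step so far to clear the scatter, though only modestly. Nothing measured here bears on what lies behind either step.

As far as these compounds go, it stays open whether a longer chain such as propyl on the saturated chain carbon would give a step beyond the scatter. From the compounds shown here alone, it also stays open how chloro or methoxy on the aromatic carbon would compare with bromo.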